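The source may report more compounds than this note shows. Statements on the series, on what has been measured and on what is new or still open speak of the compounds shown alone.

Three compounds of this series have so far been examined in an ADME assay on microsomes from liver (Mus musculus) for metabolic stability, read by LC-MS, with NADPH named in the record, with a stated time of 60 min, tested at 1 uM, in the absence of a further agent; on this read-out higher numbers stand for a more stable compound and lower numbers for a less stable compound. Compound 1 `COc1ccc(-c2c(C)sc3c(N4CC[C@@H](NC(C)=O)C4)nc(C)nc23)cc1OC` is reported only as a limit, given as > 95%. Compound 2 `COc1ccc(-c2c(C)nc3c(N4CC[C@@H](NC(C)=O)C4)cc(Cl)nn23)cc1OC` is likewise reported only as a limit, recorded as > 95%. Compound 3 `COc1ccc(-c2c(C)nc3c(N4CC[C@@H](NC(=O)NC(C)C)C4)cc(C)nn23)cc1OC` also stands at a limit rather than a number, reported as > 95%. Among the measured compounds shown here, because all three sit together at the limit of > 95% in this assay, at which 3 of the 3 values shown sit, no step between measured compounds can be drawn, and the numbers give compound 3 no place among them other than at that limit.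

Compound 4 `COc1ccc(-c2c(C)nc3c(N4CC[C@@H](SC(C)=O)C4)cc(C)nn23)cc1OC` differs from compound 3 in one place: acetylsulfanyl in place of (isopropylcarbamoyl)amino on a saturated ring carbon. For the measured compounds named here, the measured compounds offer no step that follows this change, so its size cannot be read from them. Compound 4 is nevertheless expected to leave the limit, with an estimated step of a number at least 25 percentage points lower from compound 3 to compound 4 (beyond the scatter) in this assay that is downward and beyond the scatter. Compound 4 is therefore estimated at 70%, expected to lie between 35% and 95%.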

Compound 4, percent of the compound remaining: > 95%
Compound 4: a limit, no number; the forecaster's own chance of this, stated with the estimate: 30%; middle value at least 25 percentage points away from the limit.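

In this assay compound 4 gives > 95% as a limit and not a number. No step can be read between compound 3 and compound 4, because both stand at a limit: the limit of > 95% in this assay, at which 4 of the 4 values shown sit. How far any of these compounds lies beyond that limit, and whether exchanging (isopropylcarbamoyl)amino for acetylsulfanyl changes the read-out at all, remains open.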